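This account rests on a few compounds, and the source may have more. Where it says the series, first, only, none or still open, it means among the compounds named here.

Three compounds have so far been run in a functional assay on MCF7 cells (Homo sapiens) for antiproliferative activity, read by sulforhodamine B assay, with a stated time of 72 h, tested at 30 uM; on this read-out higher numbers stand for a weaker effect at the one concentration tested and lower numbers for a stronger effect. Compound 1 `COc1cccc(C(=O)/C=C/c2cc(Br)cc(OC)c2O)c1` gives 63.1% in this assay, compound 2 `O=C(/C=C/c1cc(Br)ccc1O)c1ccc(Br)cc1` gives 28.3%, and compound 3 `COC(=O)C1=C(N)Oc2c(OC)cc(Br)cc2C1CC(=O)c1ccc(Cl)cc1` gives 33.8%. On these numbers compound 3 stands second highest of the three: its nearest neighbour is compound 2, whose value lies within the usual scatter of it, while compound 1 lies furthest away, beyond the scatter, with the higher number and hence the weaker effect.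

The next compound, compound 4 `COC(=O)C1=C(N)Oc2c(OC)cc(Br)cc2C1CC(=O)c1cccc(OC)c1`, keeps the core of compound 3 and differs from it in a single place: 3-methoxyphenyl in place of 4-chlorophenyl on a carbonyl carbon. Among the measured compounds shown here, no pair of measured compounds that differ in just one place is available, so the size of this step cannot be read from an earlier one. Compound 1 also carries a 3-methoxyphenyl on a carbonyl carbon, but on a different core, so its value offers only a loose hint. Compound 4 is expected to shift by a number 11.2 percentage points higher from compound 3 to compound 4 (beyond the scatter) in this assay, a modest move toward a weaker effect that may not clear the scatter. Compound 4 is estimated at 45%, with a range from 28% to 66%.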

Compound 4, a percentage reported as activity, at one concentration (the size of the read-out at that concentration, not a potency): 94.9%
For compound 4 the middle estimate is 49.9 percentage points below the measured one; measured number above the stated range.
By their numbers in this assay, from the lowest: compounds 2 and 3 (each within the scatter of the next); then compound 1; then compound 4.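

Among the compounds shown here, this is the first step between two measured compounds that differ in one place, and in this assay it is large: a number 61.1 percentage points higher from compound 3 to compound 4 (beyond the scatter). With the core held constant, this single exchange of groups is enough to move the read-out from a fairly strong effect to a much weaker one at the one concentration tested, so the outcome on this core is sensitive to the group at this position. No measurement available here bears on the cause of this step.

On these data alone, the change replaces chlorine with a methoxy group and also alters the number in the group's name, so this one pair cannot separate the two, and the values that 3-chlorophenyl or 4-methoxyphenyl would give on the same core remain open. Also open, as far as these compounds go, is how an unsubstituted phenyl, or a longer saturated chain in place of the ring, would behave at this position, and whether any trend holds beyond this single pair.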